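A few compounds are considered here, and "the series" means these few. Any claim that something is new, unique, unknown or untested is made for them only; others in the source may bear on it.

Compound 1, `CCn1cc(C(=O)N2N=C(c3cc4ccccc4o3)CC2c2ccccc2O)c(=O)c2ccc(C)nc21`: in an ADME assay on Vero cells (Chlorocebus sabaeus) for cytotoxicity, read by MTT assay, with a stated time of 72 h (on this read-out lower numbers stand for stronger inhibition and higher numbers for weaker inhibition), compound 1 gives > 157000 nM, a limit of the assay rather than a number.
Compound 2, `CCn1cc(C(=O)N2N=C(c3cc4ccccc4o3)CC2c2ccc(O)cc2)c(=O)c2ccc(C)nc21`: in this assay compound 2 gives > 148000 nM, again a limit of the assay.

Compound 2 therefore stands at the edge of what this assay can report; the two values shown are both limits, the limit of > 148000 nM in this assay, at which 1 of the 2 values shown sits, and (the limit of > 157000 nM in this assay, at which 1 of the 2 values shown sits), so neither compound has a measured number. For the measured compounds named here, the one comparable step, a step that the two limits leave unreadable from compound 1 to compound 2, cannot be read for the same reason. Compound 3, `CCn1cc(C(=O)N2N=C(c3cc4ccccc4o3)CC2c2ccccc2Cl)c(=O)c2ccc(C)nc21`, differs from compound 2 by 2-chlorophenyl in place of 4-hydroxyphenyl on a saturated ring carbon. Going by the values given here, no measured step bears on this change with a readable size, so the expectation rests only on the two limits. Compound 3 is expected to sit near 150000 nM in this assay, within 40000 nM to 300000 nM, and probably to come back as a limit once more. The estimated step that the limit leaves unreadable from compound 2 to compound 3 is thus expected to stay within the scatter.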

Compound 3, half-maximal inhibitory concentration: > 178000 nM
Compound 3: no number, only a limit; the forecaster's own chance of this, stated with the estimate: 70%; middle value at least 1.1-fold (0.07 log units) from the limit.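

Compound 3, like compound 1 and compound 2, gives only a limit in this assay and not a number, so the steps between these three compounds cannot be read. The compounds shown leave open whether 2-hydroxyphenyl, 4-hydroxyphenyl and 2-chlorophenyl differ at all in their effect on these cells.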